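Pyridinyl cyanoguanidine ethers as nicotinamide phosphoribosyltransferase inhibitors

The source may hold more compounds than are shown below. What is called first, only, known or untested is meant among the compounds shown, and "the series" means these compounds.

Compound 1 `C#Cc1cccc(Nc2ncnc3cc(OC)c(OCCCCCCN/C(=N\C#N)Nc4cccnc4)cc23)c1`, compound 2 `C#Cc1cccc(Nc2ncnc3cc(OC)c(OCCCCCN/C(=N\C#N)Nc4ccncc4)cc23)c1` and compound 3 `C#Cc1cccc(Nc2ncnc3cc(OC)c(OCCCCCCN/C(=N\C#N)Nc4ccncc4)cc23)c1` were examined in an assay on isolated protein for inhibition of Nicotinamide phosphoribosyltransferase (Homo sapiens), read by colorimetric assay, with stated times of 60 min, 30 min and 5 min; a lower number here means a stronger inhibitor, a higher number a weaker inhibitor. Compound 1 gives 133 nM, compound 2 gives 41.2 nM and compound 3 gives 131 nM; compound 2 shows the lowest number of the three, and both of its steps to the other two lie beyond the scatter. From compound 3 to compound 1 the change is pyridin-3-yl in place of pyridin-4-yl on an amine nitrogen, and it made a 1.0-fold higher number from compound 3 to compound 1 (0.01 log units; within the scatter). Compound 4 `C#Cc1cccc(Nc2ncnc3cc(OC)c(OCCCCCN/C(=N\C#N)Nc4cccnc4)cc23)c1` has not yet been measured in this assay; it differs from compound 2 by pyridin-3-yl in place of pyridin-4-yl on an amine nitrogen, the same change at the same place, while the difference between the cores of compound 2 and compound 3 is not broken down here. Because of a 1.0-fold higher number from compound 3 to compound 1 (0.01 log units; within the scatter) the expected step is a 1.0-fold higher number from compound 2 to compound 4 (0.01 log units; within the scatter). Compound 4 is therefore estimated at 42 nM in this assay, with a likely range from 20 nM to 90 nM.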

Compound 4, half-maximal inhibitory concentration: 74 nM
Beside the measured number, compound 4's estimate is 1.8-fold (0.25 log units) below it, and the stated range covers the measured number.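

In this assay, pyridin-3-yl in place of pyridin-4-yl on an amine nitrogen gave a 1.8-fold higher number from compound 2 to compound 4 (0.25 log units; within the scatter), so this change has no readable effect on the core of compound 2. Set against the earlier step, the change carried from one core to the other with no difference that can be told from noise: the same change on two cores in this assay, a 1.0-fold higher number (0.01 log units; within the scatter) from compound 3 to compound 1 and a 1.8-fold higher number (0.25 log units; within the scatter) from compound 2 to compound 4, 1.8-fold (0.25 log units) apart, within the scatter of two such steps. For the compounds shown here, this rests on only two cores and on steps that both lie within the scatter, so it does not show that the change would stay as small on other cores.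

The compounds shown leave open how pyridin-2-yl or an unsubstituted phenyl group would behave on the same amine nitrogen. They also leave open whether the match holds on a core with a shorter or longer chain.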